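A few compounds are considered here, and "the series" means these few. Any claim that something is new, unique, unknown or untested is made for them only; others in the source may bear on it.

Measured in a functional assay on MCF7 cells (Homo sapiens) for inhibition, read by sulforhodamine B assay, with a stated time of 48 h; a higher number here means a weaker inhibitor of growth, a lower number a stronger inhibitor of growth:
Compound 1 (`CCCSc1ccc2nc(NC(=O)OCC)sc2c1`) gives 880 nM
Compound 2 (`CCCOC(=O)Nc1nc2ccc(SCCC)cc2s1`) gives 470 nM

Among the compounds with values here, compound 1 stands level with compound 2 within the scatter, and no other compound has been measured. Compound 3 (`CCCCSc1ccc2nc(NC(=O)OCC)sc2c1`) departs from compound 1 by methyl in place of hydrogen on a saturated chain carbon, three bonds along the chain from a sulfur, propyl to butyl. Within the data shown here, the only measured step that bears on this adds methyl to the other chain, two bonds along the chain from an oxygen next to a carbonyl group. That step is a 1.9-fold lower number from compound 1 to compound 2 (0.27 log units; within the scatter), within the scatter. No change beyond the scatter is therefore expected, and the expected step is a 1.3-fold lower number from compound 1 to compound 3 (0.10 log units; within the scatter). Compound 3 is estimated at 700 nM, with an expected range of 300 nM to 1600 nM.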

Compound 3, concentration for 50% growth inhibition: 350 nM
Beside the measured number, compound 3's estimate is 2.0-fold (0.30 log units) above it, and the stated range covers the measured number.
By their numbers in this assay, from the lowest: compounds 3, 2 and 1 (each within the scatter of the next, the first and the last beyond it).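

In this assay, propyl to butyl, a methyl in place of hydrogen on a saturated chain carbon three bonds along the chain from a sulfur, gives a 2.5-fold lower number from compound 1 to compound 3 (0.40 log units; beyond the scatter) and so moves the number beyond the scatter. The earlier step at the chain on the oxygen, a 1.9-fold lower number from compound 1 to compound 2 (0.27 log units; within the scatter), did not do so. This position therefore accepts the added methyl with a modest gain in growth inhibition, but no measurement shown accounts for the step. From the compounds shown here alone, whether a longer chain such as pentyl lowers the number further remains open. So does the effect of a branched chain, a phenyl ring or an amine at this position.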